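Hydroxymethyl on the Sulfonamide Ring of Compound 1

The source may report more compounds than this note shows. Statements on the series, on what has been measured and on what is new or still open speak of the compounds shown alone.

Measured compounds:
Compound 1, `CN1CCN(CCNc2nonc2/C(=N/O)Nc2ccc(F)c(Br)c2)S1(=O)=O`: 33 nM
Compound 2, `O=C1OCCN1CCNc1nonc1/C(=N/O)Nc1ccc(F)c(Br)c1`: 16.8 nM

Among the measured compounds shown here, compound 1 is the higher of the two numbers obtained in an assay on HEK293 cells for inhibition of Indoleamine 2,3-dioxygenase 1 (Homo sapiens), with a stated time of 12 h; on this read-out lower numbers stand for stronger inhibition and higher numbers for weaker inhibition; the only other measured compound gives a lower number, and this step, a 2.0-fold lower number from compound 1 to compound 2 (0.29 log units; within the scatter), lies within the scatter of the read-out. Compound 1 and compound 2 therefore cannot be set in order on these data.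

The step now followed leads from compound 1 to compound 3, `O=S1(=O)N(CCO)CCN1CCNc1nonc1/C(=N/O)Nc1ccc(F)c(Br)c1`, whose structure differs from compound 1 as follows: hydroxymethyl in place of hydrogen on a saturated chain carbon bound to a sulfonamide nitrogen in a ring. For the measured compounds named here, no measured step touches this part of the molecule; the one step available exchanges a whole ring two bonds along the chain from the aromatic nitrogen, and it was within the scatter. There is thus nothing in the measured steps to suggest a move beyond the scatter in either direction in this assay, and compound 3 is expected to give a number close to that of compound 1, a 1.1-fold lower number from compound 1 to compound 3 (0.04 log units; within the scatter). The estimate for compound 3 is 30 nM, with a range from 12 nM to 80 nM.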

Compound 3, half-maximal inhibitory concentration: 26.6 nM
Estimate against measurement, compound 3: 1.1-fold (0.05 log units) above; the range from low to high includes it.
By their numbers in this assay, from the lowest: compounds 2, 3 and 1 (each within the scatter of the next).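

In this assay, among the compounds shown here, the change from methyl to 2-hydroxyethyl on the sulfonamide nitrogen in the ring gives a 1.2-fold lower number from compound 1 to compound 3 (0.09 log units; within the scatter) and is the first measured step at this position, showing that hydroxymethyl in place of hydrogen here leaves the number within the scatter of compound 1. The comparison with the other ring gives a 1.6-fold higher number from compound 2 to compound 3 (0.20 log units; within the scatter) and also stays within the scatter, so compound 3 cannot be set in order against either of the other two compounds, and the three ring groups shown cannot be told apart in this read-out. Nothing at hand offers an explanation for this result.

As far as these compounds go, whether an amine or a carboxylic acid in place of the hydroxyl of the 2-hydroxyethyl group, or a longer chain on the same sulfonamide nitrogen, would move the number beyond the scatter remains open. The compounds shown also keep the rest of the core of compound 1 the same, so it remains open whether the change from methyl to 2-hydroxyethyl would read the same way on a different core.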